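The source may report more compounds than this note shows. Statements on the series, on what has been measured and on what is new or still open speak of the compounds shown alone.

Measured compounds:
Compound 1, `O=C1OC(CO)(COC(=O)c2ccc([N+](=O)[O-])cc2)C/C1=C\c1ccc([N+](=O)[O-])cc1`, gives 2.22 nM in an assay on isolated protein for binding affinity to Ras guanyl-releasing protein 3 (Homo sapiens); a higher number here means a weaker inhibitor, a lower number a stronger inhibitor.
Compound 2, `CN(C)c1cccc(C(=O)OCC2(CO)C/C(=C\c3ccc([N+](=O)[O-])cc3)C(=O)O2)c1`, gives 2.3 nM in this assay.
Compound 3, `CN(C)c1cccc(C(=O)OCC2(CO)C/C(=C\c3cccc([N+](=O)[O-])c3)C(=O)O2)c1`, gives 5.3 nM in this assay.

Among these three, compound 3 carries the highest number: compound 2 sits below it by a 2.3-fold higher number from compound 2 to compound 3 (0.36 log units; beyond the scatter), and compound 1 sits further below still, both gaps beyond the scatter. The remaining measured step, a 1.0-fold higher number from compound 1 to compound 2 (0.02 log units; within the scatter), lies within the scatter.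

Compound 4, `CN(C)c1cccc(C(=O)OCC2(CO)C/C(=C\c3ccccc3[N+](=O)[O-])C(=O)O2)c1`, has not yet been measured in this assay. It differs from compound 3 in one place: 2-nitrophenyl in place of 3-nitrophenyl on a double-bonded chain carbon bound to a double-bonded ring carbon

Going by the values given here, the only measured step that touches this position is a 2.3-fold higher number from compound 2 to compound 3 (0.36 log units; beyond the scatter), a modest rise in number. Among the compounds with values here, no measured step covers the 2-nitrophenyl, so the direction of the new change is uncertain; a further modest rise or a flat result seems most plausible. Compound 4 is therefore expected to give about 7.5 nM, with a plausible range from 3 nM to 19 nM. This estimate amounts to a 1.4-fold higher number from compound 3 to compound 4 (0.15 log units; within the scatter).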

Compound 4, inhibition constant: 16.4 nM
For compound 4 the middle estimate is 2.2-fold (0.34 log units) below the measured one; the measured number falls inside the stated range.
By their numbers in this assay, from the lowest: compounds 1 and 2 (each within the scatter of the next); then compound 3; then compound 4.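

Placing the nitro group on the 2-nitrophenyl gives a 3.1-fold higher number from compound 3 to compound 4 (0.49 log units; beyond the scatter) in this assay, and set against the 4-nitrophenyl of compound 2, the same change gives a 7.1-fold higher number from compound 2 to compound 4 (0.85 log units; beyond the scatter). With all three nitrophenyl groups now compared on the same core, the number rises in the order 4-nitrophenyl, 3-nitrophenyl, 2-nitrophenyl, showing that where the nitro group stands on this ring matters and that the earlier single step did not reveal the full span. Nothing at hand explains this rise.

The compounds shown leave open whether the nitro group is needed at all, since neither a plain phenyl nor a ring carrying an amine or a nitrile appears among them. They also leave open whether the same order would hold with the 4-nitrophenyl on the carbonyl carbon, as in compound 1.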